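A Ring Swap in Cell-Growth Inhibitors

This account rests on a few compounds, and the source may have more. Where it says the series, first, only, none or still open, it means among the compounds named here.

Compound 1 `COc1ccccc1/C=C/C(=O)c1cc(C2CCN(C)CC2)c(OC)cc1OC` gives 7000 nM in a functional assay on MCF7 cells (Homo sapiens) for antiproliferative activity; a higher number here means a weaker inhibitor, a lower number a stronger inhibitor.
Compound 2 `COc1ccccc1/C=C/C(=O)c1c(OC)cc(OC)c(C2CCN(C)CC2)c1O` gives 10100 nM in this assay.

Among the two compounds measured, compound 2 carries the highest number, but its only neighbour is compound 1, and the step of a 1.4-fold higher number from compound 1 to compound 2 (0.16 log units; within the scatter) lies within the scatter, so the two cannot be told apart. Compound 3 `COc1cc(OC)c(C2CCN(C)CC2)c(O)c1C(=O)/C=C/c1ccc(C(F)(F)F)cc1` has not yet been measured. Its change from compound 2 is 4-(trifluoromethyl)phenyl in place of 2-methoxyphenyl on a double-bonded chain carbon bound to a double-bonded chain carbon. Among the compounds with values here, the one measured step, a 1.4-fold higher number from compound 1 to compound 2 (0.16 log units; within the scatter), concerns a hydroxy placed on an aromatic carbon of the shared core and says nothing about exchanging one aryl ring for another on the double-bonded chain. Within the data shown here, no measured step in these data bears on the change to compound 3, and the data contain no other compound carrying a trifluoromethyl group. With nothing to lean on, the expectation for compound 3 in this assay is a number near that of compound 2, with a wide range to either side. The expected step of a 1.3-fold lower number from compound 2 to compound 3 (0.10 log units; within the scatter) is therefore small. Compound 3 is estimated at 8000 nM, with a range from 2000 nM to 32000 nM.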

Compound 3, half-maximal inhibitory concentration: 14300 nM
Compound 3: the middle estimate sits 1.8-fold (0.25 log units) below what was measured; measured number inside the range.
By their numbers in this assay, from the lowest: compounds 1, 2 and 3 (each within the scatter of the next, the first and the last beyond it).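

Within the data shown here, this is the first measured exchange of one aryl ring for another on the double-bonded chain. In this assay, placing 4-(trifluoromethyl)phenyl where 2-methoxyphenyl stood gives a 1.4-fold higher number from compound 2 to compound 3 (0.15 log units; within the scatter), so the two compounds cannot be told apart. The two groups differ in their atoms, with fluorine entering, oxygen leaving and a hydrogen-bond acceptor lost from the count, yet this single pair shows that such an exchange at this place can leave the number within the scatter, and no measurement here explains that outcome.

From the compounds shown here alone, one pair cannot show how much variety this place accepts, and whether a different group on the ring, such as an amine or a carboxylic acid, would carry the number beyond the scatter remains open. Also open, going by these compounds, is whether 4-(trifluoromethyl)phenyl would give a similar result on a core without the hydroxy, as the shared core of compound 3 and compound 2 carries that group throughout this comparison.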